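Two Chalcone Cores and One Repeated Aryl Swap

The source may hold more compounds than are shown below. What is called first, only, known or untested is meant among the compounds shown, and "the series" means these compounds.

Compound 1 `O=C(CCl)Nc1ccc(C(=O)/C=C/c2ccc(F)cc2)cc1` carries a chloroacetamide on its core, and in a functional assay on EC9706 cells (Homo sapiens) for cytotoxicity, read by MTT assay, with a stated time of 72 h (a higher number here means a weaker inhibitor, a lower number a stronger inhibitor), compound 1 gives 8600 nM. Compound 2 `O=C(CCl)Nc1ccc(C(=O)/C=C/c2ccccc2Cl)cc1` differs from it by 2-chlorophenyl in place of 4-fluorophenyl on a double-bonded chain carbon bound to a double-bonded chain carbon. In this assay compound 2 gives 6980 nM, and the step is a 1.2-fold lower number from compound 1 to compound 2 (0.09 log units; within the scatter), so the two numbers are not distinguished from each other. Compound 3 `O=C(CSC(=S)N[C@H]1CCOC1=O)Nc1ccc(C(=O)/C=C/c2ccc(F)cc2)cc1` rests on a different core, which differs from the core of compound 1 by a group of 10 heavy atoms (5 carbon, 1 nitrogen, 2 oxygen, 2 sulfur; one five-membered non-aromatic ring with 1 hetero atom) in place of one chlorine atom, on a saturated chain carbon bound to a carbonyl carbon. In this assay compound 3 gives 46100 nM; the step is a 5.4-fold higher number from compound 1 to compound 3 (0.73 log units; beyond the scatter). Compound 3 thus has the highest number of the three measured compounds, and its steps to compound 1 and to compound 2 both lie beyond the scatter.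

Compound 4 `O=C(CSC(=S)N[C@H]1CCOC1=O)Nc1ccc(C(=O)/C=C/c2ccccc2Cl)cc1` has not yet been measured in this assay. It differs from compound 3 by 2-chlorophenyl in place of 4-fluorophenyl on a double-bonded chain carbon bound to a double-bonded chain carbon. This is the same change as that from compound 1 to compound 2, made at a place described in the same words, so it is the same change on the other core. Its only measured occurrence stayed within the scatter, and nothing among the compounds shown points to a different outcome on the core of compound 3. Compound 4 is therefore expected to give a number close to that of compound 3, the expected step being a 1.2-fold lower number from compound 3 to compound 4 (0.08 log units; within the scatter), because a 1.2-fold lower number from compound 1 to compound 2 (0.09 log units; within the scatter) was small. The estimate for compound 4 in this assay is 38000 nM, expected to fall between 20000 nM and 75000 nM.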

Compound 4, half-maximal inhibitory concentration: 34100 nM
Estimate against measurement, compound 4: 1.1-fold (0.05 log units) above, and the stated range covers the measured number.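

In this assay the exchange of 4-fluorophenyl for 2-chlorophenyl gives a 1.4-fold lower number from compound 3 to compound 4 (0.13 log units; within the scatter), and this step does not differ from its earlier occurrence on the other core: the same change on two cores in this assay, a 1.2-fold lower number (0.09 log units; within the scatter) from compound 1 to compound 2 and a 1.4-fold lower number (0.13 log units; within the scatter) from compound 3 to compound 4, 1.1-fold (0.04 log units) apart, within the scatter of two such steps. The larger change, the group of 10 heavy atoms in place of one chlorine atom on the saturated chain carbon bound to a carbonyl carbon, gives a 4.9-fold higher number from compound 2 to compound 4 (0.69 log units; beyond the scatter) and likewise matches its counterpart: the same change on two cores in this assay, a 5.4-fold higher number (0.73 log units; beyond the scatter) from compound 1 to compound 3 and a 4.9-fold higher number (0.69 log units; beyond the scatter) from compound 2 to compound 4, 1.1-fold (0.04 log units) apart, within the scatter of two such steps. Among these four compounds, then, each change has about the same size on either side of the other, but this rests on a single set of four compounds, and for the aryl exchange it shows only that a step within the scatter stayed within the scatter, not that a real effect of that exchange was carried across, nor that any other change would carry in the same way.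

The compounds shown leave open whether the agreement would hold for other aryl groups on the double-bonded chain, such as a pyridine ring or a phenyl ring bearing a methoxy group or a nitrile. They also leave open whether it would hold with an amine or a longer chain in place of the chlorine atom.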